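Extending the Ester Side Chain by One Carbon

A few compounds are considered here, and "the series" means these few. Any claim that something is new, unique, unknown or untested is made for them only; others in the source may bear on it.

Compound 1 `COc1ccc(N(C)c2nc(C)nc3ccccc23)cc1C(=O)OCCCCC[Se]C#N`: 667 nM
Compound 2 `COc1ccc(N(C)c2nc(C)nc3ccccc23)cc1OCCCCCC[Se]C#N`: 4890 nM
Compound 3 `COc1ccc(N(C)c2nc(C)nc3ccccc23)cc1C[Se]C#N`: 1110 nM

All three were measured in a functional assay on HepG2 cells (Homo sapiens) for inhibition, read by MTT assay, with a stated time of 48 h; on this read-out lower numbers stand for stronger inhibition and higher numbers for weaker inhibition. Compound 1 has the lowest number of the three; compound 3 lies nearest to it, within the scatter, and compound 2 lies furthest, beyond the scatter. Among the measured compounds shown here, the one measured step between compounds that differ in a single place is a 4.4-fold lower number from compound 2 to compound 3 (0.64 log units; beyond the scatter); it changes both the chain length and the link to the aromatic carbon, so it bears only loosely on the change at hand.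

Compound 4 `COc1ccc(N(C)c2nc(C)nc3ccccc23)cc1C(=O)OCCCCCC[Se]C#N` differs from compound 1 as follows: a group of 4 heavy atoms (2 carbon, 1 nitrogen, 1 selenium; no ring) in place of a group of 3 heavy atoms (1 carbon, 1 nitrogen, 1 selenium; no ring), on a saturated chain carbon, five bonds along the chain from an oxygen next to a carbonyl group. For the measured compounds named here, no measured step isolates a single added chain carbon, so the account rests on what the numbers show: compound 1 gives 667 nM in this assay, while compound 2, which also carries a longer chain, gives 4890 nM. A step of modest size at most is expected, and it could fall either way within the scatter.

For compound 4, the estimate in this assay is 900 nM, with a range from 350 nM to 2500 nM, which means an expected step of a 1.3-fold higher number from compound 1 to compound 4 (0.13 log units; within the scatter).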

Compound 4, half-maximal inhibitory concentration: 2650 nM
The estimate for compound 4 lay 2.9-fold (0.47 log units) below the measured number, outside the stated range (above it).
By their numbers in this assay, from the lowest: compounds 1 and 3 (each within the scatter of the next); then compounds 4 and 2 (each within the scatter of the next).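

In this assay, adding a single carbon to the ester side chain gives a 4.0-fold higher number from compound 1 to compound 4 (0.60 log units; beyond the scatter), so this place on the saturated chain, five bonds along the chain from an oxygen next to a carbonyl group, responds to one carbon even with the ester link and the shared core unchanged. This is the first step among these compounds that isolates chain length alone, and it lies beyond the scatter, whereas the earlier step changed the link as well. No measurement is available here that would account for the step.

The compounds shown leave open whether a longer chain on the ester would continue in the same direction, or whether a shorter chain would do the reverse. They also leave open whether an amide in place of the ester would respond to one added carbon in the same way.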